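Swapping 4-fluorophenyl for pyridin-4-yl in compound 4

The compounds below may be only part of what the source reports. "The series", "measured", "known", "first", "only" and "open" are said of these compounds alone.

Compound 1 (`c1ccc(CNc2nnc(-c3ccc4cnccc4c3)o2)cc1`) in an ADME assay (liver) for metabolic stability, with Liver microsome (Homo sapiens) as the target, using microsomes (on this read-out lower numbers stand for slow clearance and higher numbers for fast clearance), gives 120 mL.min-1.g-1
Compound 2 (`Nc1n[nH]c2ccc(-c3nnc(NCc4ccccc4)o3)cc12`) in this assay gives 26 mL.min-1.g-1
Compound 3 (`Fc1ccc(CNc2nnc(-c3c[nH]c4ncccc34)o2)cc1`) in this assay gives 47 mL.min-1.g-1

Microsomes are liver-derived preparations used to gauge how quickly a compound is cleared. Compound 3, at 47 mL.min-1.g-1, stands clearly under compound 1 at 120 mL.min-1.g-1 and cannot be told apart from compound 2 at 26 mL.min-1.g-1, since the two numbers lie within the usual scatter of repeated measurements.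

Compound 4 (`c1cnc2[nH]cc(-c3nnc(NCc4ccncc4)o3)c2c1`) has not yet been measured. It differs from compound 3 in one place: pyridin-4-yl in place of 4-fluorophenyl on a saturated chain carbon bound to a nitrogen on an aromatic ring.

Among the measured compounds shown here, no two measured compounds differ in only one place, so the numbers offer no direct guide to this change, and the expectation rests on the structural change alone. In this assay the estimated step is a 1.6-fold lower number from compound 3 to compound 4 (0.19 log units; within the scatter) and is expected to point modestly toward slower clearance, without going clearly beyond the scatter. Compound 4 is estimated at 30 mL.min-1.g-1 (expected range 13 mL.min-1.g-1 to 68 mL.min-1.g-1).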

Compound 4, intrinsic clearance in microsomes: < 14 mL.min-1.g-1
Compound 4 gave a limit, no number; the forecaster's own chance of this, stated with the estimate: 8%; middle value at least 2.1-fold (0.33 log units) away from the limit.
By their numbers in this assay, from the lowest: compounds 2 and 3 (each within the scatter of the next); then compound 1. At a limit, below all of these: compound 4.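

In this assay, this is the first step among the compounds shown that changes one place only, so the group on a saturated chain carbon bound to a nitrogen on an aromatic ring can now be judged on its own. Putting pyridin-4-yl in place of 4-fluorophenyl there gives an at least 3.3-fold lower number from compound 3 to compound 4 (0.52 log units; beyond the scatter), which shows that this position alone can move the read-out toward slower clearance by more than the usual scatter, something that compounds 1, 2 and 3 could not show, as they differ from one another in more than one place. Compound 4 gives a limit and not a number: the limit of < 14 mL.min-1.g-1 in this assay, at which 1 of the 4 values shown sits.

The swap changes two things at once, bringing in a ring nitrogen and removing the fluorine, so these compounds do not tell which of the two matters for the step. Also open, as far as these compounds go, is how other groups at this position, such as pyridin-3-yl or a morpholine ring, would read in this assay, and whether the same swap would give a similar step on the cores of compound 1 or compound 2.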